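Working notes on the aniline ring swap toward compound 3

A few compounds are considered here, and "the series" means these few. Any claim that something is new, unique, unknown or untested is made for them only; others in the source may bear on it.

Two compounds of the series carry numbers. Compound 1 `O=C(CSc1nc(Nc2ccccc2)c2ccccc2n1)Nc1ccc(Cl)cc1Cl` gives 8410 nM in a functional assay on NCI-H1975 cells (Homo sapiens) for inhibition, read by MTT assay, with a stated time of 72 h; on this read-out higher numbers stand for weaker inhibition and lower numbers for stronger inhibition. Compound 2 `C=CC(=O)Nc1cccc(NC(=O)CSc2nc(Nc3ccccc3C)c3ccccc3n2)c1` gives 9920 nM in this assay; compound 2 and compound 1 lie within the usual scatter of each other, so neither stands apart. Compound 3 `C=CC(=O)Nc1cccc(NC(=O)CSc2nc(Nc3ccc(Cl)cc3)c3ccccc3n2)c1` is not yet measured. It differs from compound 2 by 4-chlorophenyl in place of 2-methylphenyl on a nitrogen on an aromatic ring. Within the data shown here, no measured pair of the series isolates this change, and the two measured values offer no spread to build on. The step of a 1.1-fold lower number from compound 2 to compound 3 (0.04 log units; within the scatter) is therefore expected to stay within the scatter, in no set direction. Compound 3 is estimated at 9000 nM, with a range from 3000 nM to 27000 nM.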

Compound 3, half-maximal inhibitory concentration: 7580 nM
The estimate for compound 3 lay 1.2-fold (0.07 log units) above the measured number; low and high end bracket the measured number.
By their numbers in this assay, from the lowest: compounds 3, 1 and 2 (each within the scatter of the next).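

In this assay, among these compounds, 4-chlorophenyl in place of 2-methylphenyl on the nitrogen gives a 1.3-fold lower number from compound 2 to compound 3 (0.12 log units; within the scatter), and this is the first pair that isolates a change at this position. The step lies within the scatter, so exchanging these two rings leaves no readable shift here.

Still open, as far as these compounds go, is whether an amine or a carboxylic acid on this phenyl ring, or a longer alkyl chain in place of the ring, would move the number beyond the scatter. No supporting data bear on this result.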